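A few compounds are considered here, and "the series" means these few. Any claim that something is new, unique, unknown or untested is made for them only; others in the source may bear on it.

Working notes on the ester series built on the shared core of compound 1 `CCC/C=C/C(=O)O[C@H](CC=C(C)C)C1=CC(=O)c2c(O)ccc(O)c2C1=O`, which in an assay on HeLa cells for inhibition of DNA topoisomerase 1 (Homo sapiens) (on this read-out lower numbers stand for stronger inhibition and higher numbers for weaker inhibition), gives 153000 nM. Compound 2 `CCCCCCC(=O)O[C@H](CC=C(C)C)C1=CC(=O)c2c(O)ccc(O)c2C1=O` gives 625000 nM in this assay, and compound 3 `C=CCC/C=C/C(=O)O[C@H](CC=C(C)C)C1=CC(=O)c2c(O)ccc(O)c2C1=O` gives 126000 nM. Compound 2 stands highest of the three numbers: a 4.1-fold higher number from compound 1 to compound 2 (0.61 log units; beyond the scatter) and a 5.0-fold lower number from compound 2 to compound 3 (0.70 log units; beyond the scatter), both beyond the scatter, while a 1.2-fold lower number from compound 1 to compound 3 (0.08 log units; within the scatter) stays within it. Compound 4 `CCCCCCCCCCCCCCCC(=O)O[C@H](CC=C(C)C)C1=CC(=O)c2c(O)ccc(O)c2C1=O` is not yet measured; it differs from compound 2 by nonyl in place of hydrogen on a saturated chain carbon, six bonds along the chain from a carbonyl carbon. For the measured compounds named here, the two measured steps that touch compound 2 exchange a saturated chain on the carbonyl carbon for an unsaturated one; neither lengthens a saturated chain, so no measured step bears directly on the change to compound 4, and the estimate rests on compound 2 alone. Because compound 2 gives 625000 nM, the highest number in this assay, compound 4 is expected to sit near it or somewhat higher, a step of a 1.3-fold higher number from compound 2 to compound 4 (0.11 log units; within the scatter). The estimate for compound 4 is 800000 nM, with a range from 250000 nM to 2500000 nM.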

Compound 4, half-maximal inhibitory concentration: > 625000 nM
Compound 4 was reported as a limit (the forecaster's own chance of this, stated with the estimate: 30%); the middle value lies beyond the limit too.
By their numbers in this assay, from the lowest: compounds 3 and 1 (each within the scatter of the next); then compound 2.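

In this assay compound 4 is reported only as a limit, > 625000 nM. Nonyl in place of hydrogen on a saturated chain carbon, six bonds along the chain from a carbonyl carbon, is the first measured change that lengthens the saturated chain rather than exchanging it for an unsaturated one, and it gives a number no lower from compound 2 to compound 4 (the limit leaves the size open), so the longer chain shows no stronger inhibition here. The reading of this step rests entirely on the limit: the limit of > 625000 nM in this assay, at which 1 of the 4 values shown sits.

As far as these compounds go, how much weaker compound 4 is, if at all, stays open, and so does any trend with saturated chain length, which would need a chain such as octyl that gives a number rather than a limit. Also open, from the compounds shown here alone, is how a chain carrying an amine or a carboxylic acid in place of nonyl would read in this assay.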